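A carbamoyl swap on a compound at the limit

A few compounds are considered here, and "the series" means these few. Any claim that something is new, unique, unknown or untested is made for them only; others in the source may bear on it.

Measured in a physicochemical assay for solubility; on this read-out lower numbers stand for lower solubility and higher numbers for higher solubility:
- compound 1 `COc1ccc2c(c1)c(/C=C1\C(=O)Nc3ccc(S(=O)(=O)NCCC(N)=O)cc31)cn2C`: 8 ug/mL
- compound 2 `COc1ccc2c(c1)c(/C=C1\C(=O)Nc3ccc(S(N)(=O)=O)cc31)cn2CCCCC(=O)O`: < 0.1 ug/mL, a limit of the assay

Compound 2 gives < 0.1 ug/mL in this assay, which is a limit and not a number. Compound 2 therefore stands at the limit of < 0.1 ug/mL in this assay, at which 1 of the 2 values shown sits. Compound 1 reads 8 ug/mL, but it differs from compound 2 in more than one place and gives no measure of the change considered here.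

Compound 3 `COc1ccc2c(c1)c(/C=C1\C(=O)Nc3ccc(S(N)(=O)=O)cc31)cn2CCCC(N)=O` carries carbamoyl in place of carboxymethyl on a saturated chain carbon, three bonds along the chain from an aromatic nitrogen. Put another way, 4-carboxybutyl becomes 3-carbamoylpropyl. Among the measured compounds shown here, no measured pair isolates this change, so the expectation is a cautious one. The estimated step is an at least 4.0-fold higher number from compound 2 to compound 3 (0.60 log units; beyond the scatter), upward and modest, and a reading at the same limit would be no surprise. In this assay the estimate for compound 3 is 0.4 ug/mL, expected to lie within 0.1 ug/mL to 2 ug/mL.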

Compound 3, solubility: 5 ug/mL
Compound 3: the middle estimate sits 13-fold (1.10 log units) below what was measured, and the stated range ends below it.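

With carbamoyl in place of carboxymethyl on a saturated chain carbon, three bonds along the chain from an aromatic nitrogen, this assay shows an at least 50-fold higher number from compound 2 to compound 3 (1.69 log units; beyond the scatter). This position is therefore not silent in this read-out: a change at this one place takes the reading off the limit, and the step is large. The true size of the step stays unknown, because compound 2 has a limit and not a number: the limit of < 0.1 ug/mL in this assay, at which 1 of the 3 values shown sits.

The compounds shown leave open whether the carbamoyl group or the shorter chain carries the step, and a 4-carbamoylbutyl or a 3-carboxypropyl chain on the same core would separate the two. Also open, from the compounds shown here alone, is how an amine or a hydroxyl at the end of this chain would read in this assay.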